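Hydrazone Aryl Swap Followed in a Cytotoxicity Series

The source may report more compounds than this note shows. Statements on the series, on what has been measured and on what is new or still open speak of the compounds shown alone.

The measured compounds are these:
compound 1, `COc1ccccc1-c1nnc(-c2ccc(C(=O)N/N=C/c3ccc([N+](=O)[O-])cc3)cc2)o1`, 203000 nM in an ADME assay on THP-1 cells (Homo sapiens) for cytotoxicity; on this read-out lower numbers stand for stronger inhibition and higher numbers for weaker inhibition;
compound 2, `COc1ccccc1-c1nnc(-c2ccc(C(=O)N/N=C/c3ccc(F)cc3)cc2)o1`, 427000 nM in this assay;
compound 3, `COc1ccccc1-c1nnc(-c2ccc(C(=O)N/N=C/c3ccc(Cl)cc3Cl)cc2)o1`, 78800 nM in this assay.

Compound 2 gives the highest number of the three in this assay: compound 1 sits nearest, a 2.1-fold higher number from compound 1 to compound 2 (0.32 log units; beyond the scatter), while compound 3 lies furthest, a 5.4-fold lower number from compound 2 to compound 3 (0.73 log units; beyond the scatter).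

Compound 4, `COc1ccccc1-c1nnc(-c2ccc(C(=O)N/N=C/c3ccc(O)cc3O)cc2)o1`, has not been measured. It differs from compound 2 in one place: 2,4-dihydroxyphenyl in place of 4-fluorophenyl on a carbon with a double bond to nitrogen.

For the measured compounds named here, two measured steps touch the same carbon with a double bond to nitrogen. From compound 2 the change to compound 3 gave a 5.4-fold lower number from compound 2 to compound 3 (0.73 log units; beyond the scatter), and from compound 1 to compound 3 it gave a 2.6-fold lower number from compound 1 to compound 3 (0.41 log units; beyond the scatter). Both moved the number downward, though neither involved a hydroxyl-bearing ring, so they serve only as a loose guide. For compound 4 a small downward step is therefore expected, a 1.4-fold lower number from compound 2 to compound 4 (0.15 log units; within the scatter), hardly beyond the scatter. The estimate for compound 4 in this assay is 300000 nM, expected to fall between 120000 nM and 750000 nM.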

Compound 4, half-maximal inhibitory concentration: 104000 nM
For compound 4 the middle estimate is 2.9-fold (0.46 log units) above the measured one; measured number outside the range, below it.
By their numbers in this assay, from the lowest: compounds 3, 4 and 1 (each within the scatter of the next, the first and the last beyond it); then compound 2.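

In this assay, the 2,4-dihydroxyphenyl ring shows that on this carbon with a double bond to nitrogen a ring with hydrogen-bond donors also departs from 4-fluorophenyl, with a 4.1-fold lower number from compound 2 to compound 4 (0.61 log units; beyond the scatter). Against the other two rings, compound 4 cannot be separated: a 1.3-fold higher number from compound 3 to compound 4 (0.12 log units; within the scatter) and a 2.0-fold lower number from compound 1 to compound 4 (0.29 log units; within the scatter), so 2,4-dihydroxyphenyl reads alike with both 2,4-dichlorophenyl and 4-nitrophenyl here. For the compounds shown here, compound 2 thus remains the only compound whose steps to all three others lie beyond the scatter.

No available evidence accounts for these differences at this position. On these data alone, it remains open which of the two hydroxyl groups matters for the step, and whether a ring bearing an amine or a carboxylic acid would read the same.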